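Two chain lengths, two cores, one half-life still open

A few compounds are considered here, and "the series" means these few. Any claim that something is new, unique, unknown or untested is made for them only; others in the source may bear on it.

Compound 1 `CCC(NC(=O)c1ccc(C(=N)N)cc1)C(C)(C)C(=O)N1CCC(CC(=O)O)CC1` is the starting point of this small set. In an in vivo ADME assay on the whole organism (Cavia porcellus) (on this read-out lower numbers stand for a shorter-lived compound and higher numbers for a longer-lived compound), compound 1 gives 1.3 h. Compound 2 `CCCCC(NC(=O)c1ccc(C(=N)N)cc1)C(C)(C)C(=O)N1CCC(CC(=O)O)CC1` carries ethyl in place of hydrogen on a saturated chain carbon, three bonds along the chain from an amide-type nitrogen; in this assay compound 2 gives 1.03 h, a step of a 1.3-fold lower number from compound 1 to compound 2 (0.10 log units; within the scatter). Compound 3 `CCC(NC(=O)c1ccc(C(=N)N)cc1F)C(C)(C)C(=O)N1CCC(CC(=O)O)CC1` differs from compound 1 in the core, by fluoro in place of hydrogen on an aromatic carbon; in this assay compound 3 gives 1.48 h, a step of a 1.1-fold higher number from compound 1 to compound 3 (0.06 log units; within the scatter). The three measured numbers all lie within the usual scatter of one another, so no order among them can be read from the data.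

Compound 4 `CCCCC(NC(=O)c1ccc(C(=N)N)cc1F)C(C)(C)C(=O)N1CCC(CC(=O)O)CC1` has not yet been measured in this assay. Compared with compound 3 it shows (ethyl in place of hydrogen on a saturated chain carbon, three bonds along the chain from an amide-type nitrogen), at a place described in exactly the same words as the change from compound 1 to compound 2, so it is the same change made on the core of compound 3 rather than on the core of compound 1. For the measured compounds named here, the only guide to the size of its effect is the single earlier step, which stayed within the scatter. On that basis the step from compound 3 to compound 4 is expected to be a 1.3-fold lower number from compound 3 to compound 4 (0.11 log units; within the scatter), resting on a 1.3-fold lower number from compound 1 to compound 2 (0.10 log units; within the scatter). Compound 4 is therefore estimated to give 1.15 h in this assay, with the likely range running from 0.7 h to 1.9 h.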

Compound 4, half-life: 1.3 h
For compound 4 the middle estimate is 1.1-fold (0.05 log units) below the measured one, and the stated range covers the measured number.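

Carried onto the fluoro-bearing core, ethyl in place of hydrogen gives in this assay a 1.1-fold lower number from compound 3 to compound 4 (0.06 log units; within the scatter), and this step agrees with the earlier one: the same change on two cores in this assay, a 1.3-fold lower number (0.10 log units; within the scatter) from compound 1 to compound 2 and a 1.1-fold lower number (0.06 log units; within the scatter) from compound 3 to compound 4, 1.1-fold (0.04 log units) apart, within the scatter of two such steps. Read the other way round, fluoro in place of hydrogen on an aromatic carbon gives a 1.3-fold higher number from compound 2 to compound 4 (0.10 log units; within the scatter), and this step also agrees with its earlier counterpart: the same change on two cores in this assay, a 1.1-fold higher number (0.06 log units; within the scatter) from compound 1 to compound 3 and a 1.3-fold higher number (0.10 log units; within the scatter) from compound 2 to compound 4, 1.1-fold (0.04 log units) apart, within the scatter of two such steps. Together the two pairs show that, on these cores, neither change reads differently from one core to the other, but every step lies within the scatter, so they do not show that either change moves the half-life at all, and a change with no visible size gives little test of whether an effect carries over, nor do four compounds speak for any other core in the series.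

The compounds shown leave open whether a longer chain or a ring on the same saturated chain carbon, or chloro in place of fluoro on the aromatic carbon, would give a step beyond the scatter. They also leave open how an ester in place of the carboxylic acid would read on either core.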